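A few compounds are considered here, and "the series" means these few. Any claim that something is new, unique, unknown or untested is made for them only; others in the source may bear on it.

Measured compounds:
Compound 1 `Cc1cc(Cl)c(S(C)(=O)=O)cc1C(=O)N=C(N)N` gives 25 nM in a functional assay for inhibition of sodium/hydrogen exchanger (Oryctolagus cuniculus); on this read-out higher numbers stand for weaker inhibition and lower numbers for stronger inhibition.
Compound 2 `CCc1cc(Cl)c(S(C)(=O)=O)cc1C(=O)N=C(N)N` gives 63 nM in this assay.
Compound 3 `Cc1c(C(=O)N=C(N)N)cc(S(C)(=O)=O)c(Cl)c1C` gives 58 nM in this assay.

Compound 1 stands lowest of the three, so it is the strongest inhibitor here; the steps of a 2.5-fold higher number from compound 1 to compound 2 (0.40 log units; beyond the scatter) and a 2.3-fold higher number from compound 1 to compound 3 (0.37 log units; beyond the scatter) each raise the number modestly. Compound 4 `Cc1cc(-c2cc(Cl)cc(Cl)c2)c(S(C)(=O)=O)cc1C(=O)N=C(N)N` differs from compound 1 in one place: 3,5-dichlorophenyl in place of chloro on an aromatic carbon. Neither measured step bears directly on this change, since both add a methyl rather than replacing chloro with a larger aromatic group. The two steps only show that small additions to the core of compound 1 cost potency modestly. A larger group may be expected to cost at least as much, so in this assay compound 4 is expected at 80 nM, within 20 nM to 400 nM, a step of a 3.2-fold higher number from compound 1 to compound 4 (0.51 log units; beyond the scatter).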

Compound 4, half-maximal inhibitory concentration: 130 nM
Estimate against measurement, compound 4: 1.6-fold (0.21 log units) below; the measured number falls inside the stated range.
By their numbers in this assay, from the lowest: compound 1; then compounds 3 and 2 (each within the scatter of the next); then compound 4.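

Replacing chloro with 3,5-dichlorophenyl at this aromatic carbon, ortho to a methylsulfonyl group, gives [ a 5.2-fold higher number from compound 1 to compound 4 (0.72 log units; beyond the scatter) ]. This is the first change shown at this position, and it shows that a much larger aromatic group still leaves measurable inhibition, though weaker than with chloro. Nothing available explains this loss. The compounds shown leave open whether the added ring itself or its two chlorines set the size of the step. An unsubstituted phenyl, a methoxy group or an amine at this position would help separate these possibilities.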